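Aryl exchange on the saturated ring carbon, thiourea series

This account rests on a few compounds, and the source may have more. Where it says the series, first, only, none or still open, it means among the compounds named here.

Measured so far:
compound 1, `COc1cc(/C=C/C(=O)C2=C(/C=C/c3ccc(O)c(OC)c3)NC(=O)NC2c2ccc(C)cc2)ccc1O`; in a functional assay, with a stated time of 20 min, tested at 2 uM (a higher number here means a stronger effect of the compound at the concentration tested, a lower number a weaker effect), compound 1 gives 15.5%.
compound 2, `COc1cc(/C=C/C(=O)C2=C(/C=C/c3ccc(O)c(OC)c3)NC(=S)NC2c2ccccc2)ccc1O`; compound 2 gives 16.6%.
compound 3, `COc1cc(/C=C/C(=O)C2=C(/C=C/c3ccc(O)c(OC)c3)NC(=S)NC2c2ccc(C)cc2)ccc1O`; compound 3 gives 10.2%.

Compound 3 stands lowest of the three numbers, yet its gaps to compound 1 and to compound 2 both lie within the scatter, so no order among the three can be read from these values. For the measured compounds named here, the single step between compounds that differ in one place is a number 6.4 percentage points lower from compound 2 to compound 3 (within the scatter), which is within the scatter.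

Compound 4, `COc1cc(/C=C/C(=O)C2=C(/C=C/c3ccc(O)c(OC)c3)NC(=S)NC2c2ccccc2O)ccc1O`, is the next member. It differs from compound 3 by 2-hydroxyphenyl in place of 4-methylphenyl on a saturated ring carbon. Going by the values given here, no measured step exchanges the whole aryl group at this position, so the only guidance is indirect: the step from compound 2 to compound 3 shows that a change at this aryl group left the read-out within the scatter, and the gap between compound 1 and compound 3 is likewise within the scatter. On that basis the expected step of a number 3.8 percentage points higher from compound 3 to compound 4 (within the scatter) is none beyond the scatter. Compound 4 is therefore estimated at 14%, with an expected range from 4% to 26%.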

Compound 4, a percentage reported as activity, at one concentration (the size of the read-out at that concentration, not a potency): 34%
Compound 4: middle estimate off by 20 percentage points, on the low side; measured number above the stated range.
By their numbers in this assay, from the lowest: compounds 3, 1 and 2 (each within the scatter of the next); then compound 4.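

In this assay, the aryl group on the saturated ring carbon can move the read-out beyond the scatter: the entry of a hydroxy group on this aryl group gives a number 17.4 percentage points higher from compound 2 to compound 4 (beyond the scatter), the narrowest comparison available for this change. The wider exchange of 4-methylphenyl for 2-hydroxyphenyl gives a number 23.8 percentage points higher from compound 3 to compound 4 (beyond the scatter), whereas methyl in place of hydrogen on an aromatic carbon gave a number 6.4 percentage points lower from compound 2 to compound 3 (within the scatter), so among these three compounds only the entry of the hydroxy group registers as a real difference at this position. Nothing at hand bears on the reason for this rise.

Whether the rise is specific to hydroxy stays open, since the compounds shown include no aryl group at this carbon carrying a methoxy group, an amine or a carboxylic acid. The 2-hydroxyphenyl group also appears here only with the thiocarbonyl form of the core, so whether it gives a similar rise with the carbonyl form of compound 1 remains unknown, and a single concentration gives no potency for any of these compounds.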